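Cyclohexyl for phenyl on the chain of compound 1

The source may hold more compounds than are shown below. What is called first, only, known or untested is meant among the compounds shown, and "the series" means these compounds.

Compound 1: `CCCn1c(=O)c2nc(Cc3ccccc3)[nH]c2n(CCC)c1=O` — 891 nM
Compound 2: `Cn1c(=O)c2nc(-c3ccc(F)cc3)[nH]c2n(C)c1=O` — 1.82 nM

Two compounds carry measured numbers in an assay on isolated protein for binding affinity to adenosine receptor A1 (Rattus norvegicus); on this read-out lower numbers stand for stronger inhibition and higher numbers for weaker inhibition. Compound 1 stands at the higher of the two, and compound 2 sits far lower; since the two differ in more than one place, the gap between them cannot be tied to any single change, and nothing more than the two values themselves can be read from it.

Compound 3, `CCCn1c(=O)c2nc(CC3CCCCC3)[nH]c2n(CCC)c1=O`, is not yet measured. It differs from compound 1 in one place: cyclohexyl in place of phenyl on a saturated chain carbon bound to an aromatic carbon. Read one bond further out, the change is benzyl to cyclohexylmethyl. Among the measured compounds shown here, no measured pair in this set shows such a change, so the expectation rests on the structural change alone and on the position of compound 1 at the weaker end of this assay.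

The expected step is a moderate move toward stronger inhibition, a 3.0-fold lower number from compound 1 to compound 3 (0.47 log units; beyond the scatter), beyond the usual scatter but not large. In this assay compound 3 is therefore estimated at 300 nM, with a range from 80 nM to 1500 nM.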

Compound 3, inhibition constant: 38.9 nM
The estimate for compound 3 lay 7.7-fold (0.89 log units) above the measured number, outside the stated range (below it).
By their numbers in this assay, from the lowest: compound 2; then compound 3; then compound 1.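

In this assay, among the compounds shown here, the exchange of phenyl for cyclohexyl on a saturated chain carbon bound to an aromatic carbon gives a 23-fold lower number from compound 1 to compound 3 (1.36 log units; beyond the scatter) and is the first step in this set that can be tied to a single change. The two groups match in heavy atoms, in their lack of hydrogen-bond donors and acceptors, and in having no net charge, while the computed comparison separates them by the aromatic character of the ring, so the large step comes with a change that leaves those counts untouched. An aromatic ring at this position is therefore not needed for a much lower number than that of compound 1, and nothing at hand gives a measured property that would explain the step.

For the compounds shown here, the single pair leaves open whether the same exchange would give a step of similar size on a core carrying methyl groups in place of the propyl chains of compound 1 and compound 3. It also leaves open how the number would respond to a cyclopentyl ring, a longer chain between the ring and the core, or an amine on the cyclohexyl ring.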